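Changing the aryl amine in a dimethoxyphenyl urea series

The source may hold more compounds than are shown below. What is called first, only, known or untested is meant among the compounds shown, and "the series" means these compounds.

Of the compounds shown here, three share a pyrimidine urea core and have been tested in a functional assay on HCC827 cells (Homo sapiens) for inhibition, read by MTT assay, with a stated time of 48 h, tested at 10 uM; on this read-out higher numbers stand for more inhibition at the one concentration tested (going by the name of the read-out) and lower numbers for less inhibition. Compound 1 `Cc1cc(F)cc(Nc2cc(NC(=O)Nc3c(Cl)cccc3Cl)ncn2)c1` gives 49.1%. Compound 2 `COc1cc(NC(=O)Nc2cc(Nc3cccc(C(C)(C)C)c3)ncn2)cc(OC)c1` gives 48.7%, and compound 3 `CCc1ccc(Nc2cc(NC(=O)Nc3c(Cl)cccc3Cl)ncn2)cc1` gives 58%. Compound 2 sits within the scatter of both others, so the three numbers cannot be told apart. Compound 4 `COc1cc(NC(=O)Nc2cc(Nc3cc(C)cc(F)c3)ncn2)cc(OC)c1` differs from compound 2 in one place: 3-fluoro-5-methylphenyl in place of 3-(tert-butyl)phenyl on a nitrogen on an aromatic ring. Among the compounds with values here, the only measured step at that position, a number 8.9 percentage points higher from compound 1 to compound 3 (within the scatter), swaps a different pair of groups on a different urea partner and stays within the scatter, so it gives no direct guide. For compound 4 a step of a number 0.3 percentage points higher from compound 2 to compound 4 (within the scatter) is therefore expected, nothing beyond the scatter. Compound 4 is estimated at 49%, between 36% and 62%.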

Compound 4, a percentage reported as inhibition, at one concentration (the size of the read-out at that concentration, not a potency): 62.1%
The estimate for compound 4 lay 13.1 percentage points below the measured number, outside the stated range (above it).
By their numbers in this assay, from the lowest: compounds 2, 1, 3 and 4 (each within the scatter of the next, the first and the last beyond it).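

Within the data shown here, with the dimethoxyphenyl urea held constant, this is the first change at the aryl group on the nitrogen that clears the scatter: in this assay, 3-fluoro-5-methylphenyl in place of 3-(tert-butyl)phenyl gives a number 13.4 percentage points higher from compound 2 to compound 4 (beyond the scatter). Among these compounds, the position therefore responds to the group placed on it, which the earlier compounds could not show. Nothing available here explains this step.

Still open, from the compounds shown here alone, is whether the fluorine, the methyl or the loss of the tert-butyl carries the step. A 3-methylphenyl or a 3-fluorophenyl at this position would help to separate them.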